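The source may hold more compounds than are shown below. What is called first, only, known or untested is meant among the compounds shown, and "the series" means these compounds.

Working notes on the series: compound 1 `C=CC(=O)Nc1cccc(Nc2ncnc(Nc3ccc(-c4cccnc4)cc3)n2)c1`, compound 2 `C=CC(=O)Nc1cccc(Nc2ncnc(Nc3ccc(C(=O)Nc4ccccn4)cc3)n2)c1` and the unmeasured compound 3 `C=CC(=O)Nc1cccc(Nc2ncnc(Nc3ccc(OC)cc3)n2)c1` share one core. In a functional assay on Ramos cells (Homo sapiens) for antiproliferative activity, read by CCK-8 assay, with a stated time of 24 h (a higher number here means a weaker inhibitor, a lower number a stronger inhibitor), compound 1 gives > 100000 nM, which is a limit of the assay and not a number (the limit of > 100000 nM in this assay, at which 1 of the 2 values shown sits). Compound 2 has no result in this assay, recorded as "not determined" (no result reported). Among the measured compounds shown here, compound 2 thus stands on no number; the only value shown is the limit of compound 1. The change to compound 3 is methoxy in place of (pyridin-2-yl)carbamoyl on an aromatic carbon, para to a large group. For the measured compounds named here, with no measured step, no direction or size of change in this assay can be set beyond the scatter. Compound 3 is expected near 50000 nM, within 8000 nM to 150000 nM.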

Compound 3, half-maximal inhibitory concentration: 90000 nM
Estimate against measurement, compound 3: 1.8-fold (0.26 log units) below; measured number inside the range.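

In this assay, among the compounds shown here, compound 3, with methoxy on this aromatic carbon, gives 90000 nM as the first true number. Methoxy in place of pyridin-3-yl gives an at least 1.1-fold lower number from compound 1 to compound 3 (0.04 log units; that floor lies within the scatter) so this change shows no shift beyond the scatter, and that figure is only a floor. Compound 1 remains a limit of the assay and not a number: the limit of > 100000 nM in this assay, at which 1 of the 3 values shown sits.

The step between compound 2 and compound 3 cannot be read. As far as these compounds go, whether an amine or a carboxylic acid at this position would give a clearly lower number stays open.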